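The source may hold more compounds than are shown below. What is called first, only, known or untested is meant among the compounds shown, and "the series" means these compounds.

For the measured compounds named here, compound 1 `O=S(=O)(CCC(F)(Cl)C(F)(F)Cl)c1nc2ccccc2s1` gives one of only two full numbers in a functional assay on MCF7 cells (Homo sapiens) for cytotoxicity, read by MTT assay, with a stated time of 48 h; on this read-out lower numbers stand for stronger inhibition and higher numbers for weaker inhibition. In this assay compound 1 gives 10100 nM, the higher of those two numbers. Compound 3 `O=S(=O)(CCC(F)(Cl)C(F)(F)Cl)c1nc2ccc(Cl)cc2s1`, which differs only by chloro in place of hydrogen on an aromatic carbon, gives 8400 nM, and the step of a 1.2-fold lower number from compound 1 to compound 3 (0.08 log units; within the scatter) lies within the scatter. For compound 2 `O=S(=O)(CCC(F)=C(F)F)c1ccccn1` this assay reports only a limit, > 120000 nM, so no number is known for it. That result is the limit of > 120000 nM in this assay, at which 1 of the 3 values shown sits.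

Compound 4 `O=S(=O)(CCC(F)=C(F)F)c1nc2ccccc2s1` differs from compound 1 by 1,2,2-trifluoroethenyl in place of 1,2-dichloro-1,2,2-trifluoroethyl on a saturated chain carbon, two bonds along the chain from a sulfonyl sulfur. Going by the values given here, no measured step covers this change: the only measured step, from compound 1 to compound 3, concerns the aromatic ring and was within the scatter, so it says nothing about the chain. Compound 2 carries the same 1,2,2-trifluoroethenyl group on a different core and reached only a limit, which leans the expectation toward weaker inhibition, but that comparison mixes two changes at once. Compound 4 is therefore expected to give 40000 nM, within a wide range from 10000 nM to 150000 nM. For compound 4 the expected step is a 4.0-fold higher number from compound 1 to compound 4 (0.60 log units; beyond the scatter), with a real chance that only a limit is reported.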

Compound 4, half-maximal inhibitory concentration: 7200 nM
Estimate against measurement, compound 4: 5.6-fold (0.74 log units) above; the measured number lies below the stated range.
By their numbers in this assay, from the lowest: compounds 4, 3 and 1 (each within the scatter of the next). At a limit, above all of these: compound 2.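

On a saturated chain carbon, two bonds along the chain from a sulfonyl sulfur, 1,2,2-trifluoroethenyl can replace 1,2-dichloro-1,2,2-trifluoroethyl on the core of compound 1, and in this assay this exchange gives a 1.4-fold lower number from compound 1 to compound 4 (0.15 log units; within the scatter). For the compounds shown here, the earlier measured step concerned the aromatic ring, so this is the first reading at the chain, and it shows that going from 7 heavy atoms to 5, with both chlorines gone and a double bond added, leaves the number within the scatter. The same 1,2,2-trifluoroethenyl group sits on a different core in compound 2, and there the result is a limit rather than a number: the limit of > 120000 nM in this assay, at which 1 of the 4 values shown sits.

Going by these compounds alone, with only one pair of compounds at this position, it remains open whether the end of the chain matters at all for this cytotoxicity, and an amine, a carboxylic acid or a simple trifluoromethyl group in its place would test that. From the compounds shown here alone, it is also open whether chloro on the aromatic ring, as in compound 3, would give a similar result when combined with the 1,2,2-trifluoroethenyl group.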